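Pyrazole series at EP1: from amide to carbamate

This account rests on a few compounds, and the source may have more. Where it says the series, first, only, none or still open, it means among the compounds named here.

Measured compounds:
- compound 1 `Cc1cc(C(=O)O)nn1C(C)c1cc(Cl)ccc1OCc1ccccc1` — 10 nM
- compound 2 `Cc1cc(C(=O)NCc2ccncc2)nn1Cc1cc(Cl)ccc1OCc1ccccc1` — 79.4 nM
- compound 3 `Cc1cc(C(=O)NN2CCOCC2)nn1Cc1cc(Cl)ccc1OCC(C)C` — 251 nM

In an assay on CHO-K1 cells for displacement of a labelled ligand from prostaglandin E2 receptor EP1 subtype (Homo sapiens) (on this read-out higher numbers stand for weaker inhibition and lower numbers for stronger inhibition), compound 1 gives 10 nM, compound 2 gives 79.4 nM and compound 3 gives 251 nM. Compound 2 stands second highest of the three numbers: its nearest neighbour is compound 3, with a higher number beyond the scatter, and the furthest is compound 1, with a lower number beyond the scatter. Among the compounds with values here, no pair of measured compounds differs in one place only, so no single-point step is available, and the three values are taken as they stand.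

Compound 4 `Cc1cc(NC(=O)O[C@H]2CCOC2)nn1Cc1cc(Cl)ccc1OCc1ccccc1` is not yet measured. It differs from compound 2 in one place: (((oxolan-3-yl)oxy)carbonyl)amino in place of ((pyridin-4-yl)methyl)carbamoyl on an aromatic carbon. The benzyloxy and chloro substitution of the benzyl arm is kept, so the change is confined to the group on the five-membered aromatic ring.

Within the data shown here, with no measured step of this kind, the expected change is small: compound 4 is expected to give a step of a 1.9-fold higher number from compound 2 to compound 4 (0.28 log units; within the scatter) that may fall within the scatter or slightly toward a higher number. The estimate for compound 4 in this assay is 150 nM, with a range from 40 nM to 600 nM.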

Compound 4, half-maximal inhibitory concentration: 79.4 nM
For compound 4 the middle estimate is 1.9-fold (0.28 log units) above the measured one, within the range that was stated.
By their numbers in this assay, from the lowest: compound 1; then compounds 2 and 4 (each within the scatter of the next); then compound 3.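

In this assay, within the data shown here, replacing ((pyridin-4-yl)methyl)carbamoyl with (((oxolan-3-yl)oxy)carbonyl)amino on this aromatic carbon gives no change at the digits printed from compound 2 to compound 4 (within the scatter), the first one-place comparison. At this position, with the benzyloxy and chloro substitution held constant, the read-out therefore does not separate two groups that differ in their ring, one six-membered and aromatic with 1 hetero atom, the other five-membered and non-aromatic with 1 hetero atom, and in whether the carbonyl or the nitrogen is bonded to the aromatic carbon. No supporting measurement accounts for this match, and one pair cannot show which features of either group matter.

The compounds shown leave open whether the defined stereocentre counts, since the opposite configuration of the oxolan-3-yl group is absent from them, and whether an open-chain ethyl carbamate would match the ring-bearing group. They also leave open how a carboxylic acid at this position, as carried by compound 1, would read on the unbranched benzyl arm of compound 2, since compound 1 differs from it in more than one place.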